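Replacing a methyl with 4-chlorophenyl on a shared pyrazole core

This account rests on a few compounds, and the source may have more. Where it says the series, first, only, none or still open, it means among the compounds named here.

Of the compounds shown here, two have been measured so far in a functional assay on the whole organism (strain albino) for inhibition, with Rattus norvegicus as the target, read by paw edema, with stated times of 2 h and 1 h, at a dose of 100 mg/kg by the oral route; a lower number here means less inhibition, a higher number more inhibition at the dose given (going by the name of the read-out). Compound 1, `Cc1cc(-c2ccc(Cl)cc2)n(-c2ccc(S(=O)(=O)Nc3nccs3)cc2)n1`, gives 44.3% in this assay. Compound 2, `Cc1cc(C)n(Cc2nnc(Nc3ccc([N+](=O)[O-])cc3)s2)n1`, gives 50% in this assay. Going by the values given here, of these two numbers the one for compound 2 is the larger, yet the gap between compound 2 and compound 1 is within the usual scatter, so the two cannot be ranked against each other. Among the compounds with values here, no step between compounds differing in a single place has been recorded, so nothing directly tells how this change will act.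

The next compound, compound 3, is `Cc1cc(-c2ccc(Cl)cc2)n(Cc2nnc(Nc3ccc([N+](=O)[O-])cc3)s2)n1`. It differs from compound 2 as follows: 4-chlorophenyl in place of methyl on an aromatic carbon. Compound 1 carries the same 4-chlorophenyl group on its own core, but its other parts differ from those of compound 3, so its value cannot be read as a step. Within the data shown here, with no recorded step to lean on, the expected change from compound 2 to compound 3 is small, of the order of the scatter, with no clear direction: no change at the digits printed from compound 2 to compound 3 (within the scatter). Compound 3 is therefore estimated at 50% in this assay, with a range from 32% to 66%.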

Compound 3, a percentage reported as inhibition, in the whole organism at one dose (the size of the read-out at that dose, not a potency): 45%
For compound 3 the middle estimate is 5 percentage points above the measured one, within the range that was stated.
By their numbers in this assay, from the lowest: compounds 1, 3 and 2 (each within the scatter of the next).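

In this assay, the first single-place step now on record, placing 4-chlorophenyl in place of methyl on an aromatic carbon of the shared core gives a number 5 percentage points lower from compound 2 to compound 3 (within the scatter). At this position, next to the ring nitrogen, one carbon thus gives way to a group of seven heavy atoms with a six-membered aromatic ring, and the read-out at this single dose does not separate the two compounds. The compounds shown offer nothing that could explain this result.

They leave open whether a smaller or differently built group at this position, such as an amine, a carboxylic acid or a longer chain, would produce a step beyond the scatter. They also leave open whether 4-chlorophenyl in place of methyl would read the same way on the core of compound 1, and whether the closeness of compound 2 and compound 3 at this dose would hold at other doses.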